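The compounds below may be only part of what the source reports. "The series", "measured", "known", "first", "only" and "open" are said of these compounds alone.

Measured so far:
- compound 1 `CCCCCCCCCCCC(=O)OC[C@H](CSC[C@@H](N)C(=O)NCCOCCOS(=O)(=O)O)OC(=O)CCCCCCCCCCC`: in an assay on HEK293 cells for agonist activity at Toll-like receptor 2 (Homo sapiens) (on this read-out higher numbers stand for an effect only at larger amounts of compound and lower numbers for an effect already at smaller amounts), compound 1 gives 61 nM
- compound 2 `CCCCCCCCCCCC(=O)OC[C@H](CSC[C@@H](N)C(=O)NC(C)c1ccccc1)OC(=O)CCCCCCCCCCC`: compound 2 gives 9900 nM
- compound 3 `CCCCCCCCCCCC(=O)OC[C@H](CSC[C@@H](N)C(=O)NC(C)CCC(C)C)OC(=O)CCCCCCCCCCC`: compound 3 gives 190 nM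

Compound 3 stands second of the three numbers, separated from compound 1 by a 3.1-fold higher number from compound 1 to compound 3 (0.49 log units; beyond the scatter) and from compound 2 by a 52-fold lower number from compound 2 to compound 3 (1.72 log units; beyond the scatter). All three share one core and differ only in the group on the amide-type nitrogen.

Compound 4 `CCCCCCCCCCCC(=O)OC[C@H](CSC[C@@H](N)C(=O)NC(CC)COC)OC(=O)CCCCCCCCCCC` is the next step from compound 3: 1-(methoxymethyl)propyl in place of 1,4-dimethylpentyl on an amide-type nitrogen. The steps seen so far show that a branched chain on this nitrogen keeps the number fairly close to that of compound 1, while a phenyl-bearing group raises it sharply, as in a 160-fold higher number from compound 1 to compound 2 (2.21 log units; beyond the scatter). Compound 4 keeps a branched chain of similar size and adds one oxygen, so the expected step of a 1.3-fold lower number from compound 3 to compound 4 (0.10 log units; within the scatter) is small, with no clear direction beyond the scatter. Compound 4 is therefore estimated at 150 nM, within a range from 40 nM to 600 nM.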

Compound 4, half-maximal effective concentration: 71.8 nM
The estimate for compound 4 lay 2.1-fold (0.32 log units) above the measured number; measured number inside the range.
By their numbers in this assay, from the lowest: compounds 1 and 4 (each within the scatter of the next); then compound 3; then compound 2.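

Replacing 1,4-dimethylpentyl with 1-(methoxymethyl)propyl on the amide-type nitrogen gives a 2.6-fold lower number from compound 3 to compound 4 (0.42 log units; beyond the scatter) and shows that a swap between two branched chains of similar size, one of which brings in an oxygen, can move the number beyond the scatter. Compound 4 has no sulfooxy group, yet a 1.2-fold higher number from compound 1 to compound 4 (0.07 log units; within the scatter) shows that a group without it can match the 2-(2-(sulfooxy)ethoxy)ethyl group of compound 1 at this position. The 1-phenylethyl group of compound 2 stays far apart, with a 140-fold lower number from compound 2 to compound 4 (2.14 log units; beyond the scatter) on record, and nothing available explains any of these steps.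

Compound 4 differs from compound 3 in both its carbon chain and its oxygen, which leaves the share of the oxygen unsettled. On these data alone, how a group carrying an amine or a carboxylic acid on this nitrogen would compare remains open, as does a longer chain.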